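The compounds below may be only part of what the source reports. "The series", "measured", "known", "first", "only" and "open" are said of these compounds alone.

Compound 1 `O=C(O)CC[C@H](NC(=O)[C@]1(O)C[C@@H](O)[C@@H](O)[C@H](O)C1)C(=O)O`: in an assay on HL-60 cells for inhibition of E-selectin (Homo sapiens) (on this read-out higher numbers stand for weaker inhibition and lower numbers for stronger inhibition), compound 1 gives > 50000000 nM, which is a limit of the assay rather than a number.
Compound 2 `C[C@H](NC(=O)[C@]1(O)C[C@@H](O)[C@@H](O)[C@H](O)C1)C(=O)O`: in this assay compound 2 gives > 50000000 nM, again a limit and not a number.

Compound 2 therefore has no measured number at all; it sits at the limit, as does compound 1, and the limit of > 50000000 nM in this assay, at which 2 of the 2 values shown sit, gathers both of the values shown. Going by the values given here, the single step between measured compounds, a step that the two limits leave unreadable from compound 1 to compound 2, cannot be read, so nothing about the size of any change to this part of the molecule is known.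

Compound 3 `O=C(O)[C@H](CO)NC(=O)[C@]1(O)C[C@@H](O)[C@@H](O)[C@H](O)C1` differs from compound 2 by hydroxy in place of hydrogen on a saturated chain carbon, two bonds along the chain from an amide-type nitrogen and a carbonyl carbon. Among the compounds with values here, no measured step bears on this change, and the only comparison available shows two limits. With no readable step, the expected change from compound 2 to compound 3 is taken as a number no higher from compound 2 to compound 3 (the limit leaves the size open), meaning no change beyond the scatter. Compound 3 is therefore estimated at 50000000 nM, with a range from 10000000 nM to 200000000 nM, and most likely the assay will again report only a limit.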

Compound 3, half-maximal inhibitory concentration: > 50000000 nM
Compound 3: only a limit was reported (the forecaster's own chance of this, stated with the estimate: 85%); the middle value sits exactly at the limit.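

Compound 3 joins compound 1 and compound 2 at a limit of the assay rather than a number, so no step among these three compounds can be read: the limit of > 50000000 nM in this assay, at which 3 of the 3 values shown sit.

What the compounds shown leave open is whether any change to this side chain alters inhibition in this assay.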